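From hydroxy to methoxy: compound 2 to compound 3

This account rests on a few compounds, and the source may have more. Where it says the series, first, only, none or still open, it means among the compounds named here.

Compound 1 `C=CC(C)(O)CC[C@@H]1C(=C)CC[C@H](Br)[C@@]1(C)CCC(Br)C(C)(C)O` gives > 100000 nM; 60700 nM (2 entries)
Compound 2 `C=CC(C)(O)CC[C@@H]1C(=C)CC[C@H](Br)[C@@]1(C)CCC(O)C(C)(C)O` gives > 100000 nM
Compound 3 `C=CC(C)(O)CC[C@@H]1C(=C)CC[C@H](Br)[C@@]1(C)CCC(OC)C(C)(C)O` is not yet measured

In a functional assay on MCF7 cells (Homo sapiens) for cytotoxicity, read by MTT assay, with a stated time of 48 h (on this read-out lower numbers stand for stronger inhibition and higher numbers for weaker inhibition), compound 2 stands at > 100000 nM as a limit of the assay, not a number. Compound 1 gives > 100000 nM; 60700 nM (2 entries) in this assay. Behind that stand (the several entries of compound 1 in this assay, > 100000 nM; 60700 nM (2 entries)), one of them a limit of the assay and the other a number.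

Going from compound 2 to compound 3 brings one change, (methyl in place of hydrogen on an oxygen on a saturated carbon), with methyl in place of hydrogen on an oxygen on a saturated carbon, so that hydroxy becomes methoxy. For the measured compounds named here, no two measured compounds differ in one place, so the data give no measured step to set the size of this one. No step beyond the scatter is expected in this assay, and neither direction is favoured. That expectation rests on compound 2 with its limit of > 100000 nM alone. The estimated change, an at least 1.1-fold lower number from compound 2 to compound 3 (0.04 log units; that floor lies within the scatter), is therefore only a rough guide. For compound 3 the expected value is 90000 nM, with an estimated range from 40000 nM to 200000 nM, and the measurement may yet return only a limit.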

Compound 3, half-maximal inhibitory concentration: > 100000 nM
Compound 3: only a limit was reported (the forecaster's own chance of this, stated with the estimate: 60%); middle value at least 1.1-fold (0.04 log units) from the limit.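

In this assay compound 3 gives > 100000 nM as a limit of the assay, not a number. Compound 2 carries the same limit, so no step can be read between compound 2 and compound 3: the limit of > 100000 nM in this assay, at which 2 of the 3 values shown sit. The compounds shown leave open whether going from hydroxy to methoxy changes the value at all.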